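This account rests on a few compounds, and the source may have more. Where it says the series, first, only, none or still open, it means among the compounds named here.

Measured compounds:

Compound 1 `C#CCCOC(=O)c1ccc(C(CC)(CC)c2ccc(OCCC(O)(CC)CC)c(C)c2)n1CC` — > 50000 nM
Compound 2 `CCOC(=O)C(CC(=O)OC)NC(=O)c1ccc(C(CC)(CC)c2ccc(OCCC(O)(CC)CC)c(C)c2)n1CC` — > 50000 nM

In a functional assay on HepG2 cells (Homo sapiens) for antiproliferative activity, read by MTT assay, with a stated time of 48 h (a higher number here means a weaker inhibitor, a lower number a stronger inhibitor), compound 1 reaches only the limit of the assay, > 50000 nM. Compound 2 likewise gives only a limit in this assay, > 50000 nM. Both values sit at the same limit, (the limit of > 50000 nM in this assay, at which 2 of the 2 values shown sit), so the step that the two limits leave unreadable from compound 1 to compound 2 cannot be read, and compound 1 stands on a limit rather than a number.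

Compound 3 `CCn1c(C(=O)NC(C)C(=O)O)ccc1C(CC)(CC)c1ccc(OCCC(O)(CC)CC)c(C)c1` has not been measured in this assay. It differs from compound 1 as follows: (1-carboxyethyl)amino in place of (but-3-yn-1-yl)oxy on a carbonyl carbon. Going by the values given here, the one measured step, from compound 1 to compound 2, also replaces the ester part on that carbonyl carbon with an amino-acid-derived carbamoyl group and is unreadable, so no size of effect can be drawn from it. Among the compounds with values here, no measured step bears on the change in a readable way; a number for compound 3 is therefore expected only as an estimate, a number no higher from compound 1 to compound 3 (the limit leaves the size open), with no direction beyond the scatter. Compound 3 is expected to give 50000 nM in this assay, within 20000 nM to 100000 nM, most probably again reported as a limit.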

Compound 3, half-maximal inhibitory concentration: 1740 nM
Beside the measured number, compound 3's estimate is 29-fold (1.46 log units) above it; the measured number lies below the stated range.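

On the carbonyl carbon, the result gives the first readable effect of a change in the series: in this assay, (1-carboxyethyl)amino in place of (but-3-yn-1-yl)oxy gives an at least 28-fold lower number from compound 1 to compound 3 (1.45 log units; beyond the scatter). On the amide-type nitrogen, a group of 5 heavy atoms in place of a group of 11 heavy atoms gives an at least 28-fold lower number from compound 2 to compound 3 (1.45 log units; beyond the scatter), so a carbamoyl link alone does not give the lower number, as compound 2 carries one too. The step between the two earlier compounds cannot be read, and both new steps give only a lower bound on size: the limit of > 50000 nM in this assay, at which 2 of the 3 values shown sit.

Compound 3 is the only compound here with a number, so the compounds shown do not tell whether the lower number depends on the carboxylic acid itself. The methyl ester of the same group, or a longer chain in place of the methyl branch, would test this.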